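The compounds below may be only part of what the source reports. "The series", "measured", "known", "first", "only" and "open" are said of these compounds alone.

Compound 1 `O=C1/C(=C/c2ccc(F)cc2)CCC/C1=C\c1cccc([N+](=O)[O-])c1`, compound 2 `O=C1/C(=C/c2ccc(F)cc2)CCC/C1=C\c1ccccc1[N+](=O)[O-]` and compound 3 `O=C1/C(=C/c2ccc(Cl)cc2)CCC/C1=C\c1ccccc1[N+](=O)[O-]` were examined in a functional assay on MOLT-4 cells (Homo sapiens) for cytotoxicity, with a stated time of 72 h; a higher number here means a weaker inhibitor, a lower number a stronger inhibitor. In that assay compound 1 gives 5120 nM, compound 2 gives 1870 nM and compound 3 gives 3860 nM. Compound 1 and compound 2 are built from the same atoms joined differently, and the difference between their two cores is not broken down here; the two values simply stand as they are, with compound 1 the higher of the pair. Compound 1 and compound 3 lie within the scatter of one another, so no order between them is claimed.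

Compound 3 differs from compound 2 by one change, (chloro in place of fluoro on an aromatic carbon). This change brought a 2.1-fold higher number from compound 2 to compound 3 (0.31 log units; beyond the scatter) in this assay, a modest shift that nonetheless lies beyond the scatter.

Compound 4 `O=C1/C(=C/c2ccc(Cl)cc2)CCC/C1=C\c1cccc([N+](=O)[O-])c1` has not yet been measured. It stands to compound 1 exactly as compound 3 stands to compound 2: the difference is chloro in place of fluoro on an aromatic carbon, the same change on the same kind of position. Going by the values given here, on the strength of the single earlier example, in which compound 3 moved away from compound 2 by a 2.1-fold higher number from compound 2 to compound 3 (0.31 log units; beyond the scatter), the step from compound 1 to compound 4 in this assay is expected to be about a 2.1-fold higher number from compound 1 to compound 4 (0.31 log units; beyond the scatter). Among the compounds with values here, compound 4 is therefore estimated at 10500 nM, with a likely range from 5000 nM to 22000 nM, the width reflecting that only one prior instance of this change is available.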

Compound 4, half-maximal inhibitory concentration: 2020 nM
Beside the measured number, compound 4's estimate is 5.2-fold (0.72 log units) above it, outside the stated range (below it).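

In this assay, putting 4-chlorophenyl in place of 4-fluorophenyl on the core of compound 1 brought a 2.5-fold lower number from compound 1 to compound 4 (0.40 log units; beyond the scatter) and so ran against the step seen on the core of compound 2. The two instances of the change differ in direction as well as in size, so among these four compounds the result on one core did not carry over to the other: the same change on two cores in this assay, a 2.1-fold higher number (0.31 log units; beyond the scatter) from compound 2 to compound 3 and a 2.5-fold lower number (0.40 log units; beyond the scatter) from compound 1 to compound 4, 5.2-fold (0.72 log units) apart, beyond the scatter of two such steps. This shows that, in this small set, the outcome of chloro in place of fluoro depends on the core that carries it, but it does not show why the direction reverses, and two pairs cannot tell which of them is the more usual case for the series.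

The compounds shown carry only fluoro or chloro on the one aromatic ring and a nitro group on the other, so it remains open whether a bromo, methyl or methoxy group in that place, or an amine in place of the nitro group, would follow either of the two cores. From the compounds shown here alone, it also remains open whether the reversal would appear again in any other cell line or test.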